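The source may report more compounds than this note shows. Statements on the series, on what has been measured and on what is new or still open speak of the compounds shown alone.

Measured compounds:
compound 1, `O=C(c1ccccc1)N1N=C(c2cc3ccccc3oc2=O)CC1c1ccccc1`, in a functional assay on HepG2 cells (Homo sapiens) for cytotoxicity, read by MTT assay, with a stated time of 48 h (a lower number here means a stronger inhibitor, a higher number a weaker inhibitor), gives 36600 nM
compound 2, `O=C(CCl)N1N=C(c2cc3ccccc3oc2=O)CC1c1ccccc1`, gives 2980 nM
compound 3, `O=c1oc2ccccc2cc1C1=NN(S(=O)(=O)c2ccc([N+](=O)[O-])cc2)C(c2ccccc2)C1`, is reported as "not active" (no number reported), with no number

For the measured compounds named here, compound 3 therefore stands on no number in this assay; only compounds 1 and 2 carry values, and the one measured step, a 12-fold lower number from compound 1 to compound 2 (1.09 log units; beyond the scatter), concerns a change on a carbonyl carbon, not the part of the structure that differs between compound 3 and compound 4. Compound 4, `Cc1ccc(S(=O)(=O)N2N=C(c3cc4ccccc4oc3=O)CC2c2ccccc2)cc1`, differs from compound 3 by methyl in place of nitro on an aromatic carbon. No measured step bears on this change, so no direction can be read from the numbers shown; with compound 3 reported inactive, a weak result is expected. Compound 4 is estimated at 40000 nM, within 8000 nM to 200000 nM.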

Compound 4, half-maximal inhibitory concentration: "not active" (no number reported)
Compound 4 has no reported number here, and the estimate cannot be compared.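

Compound 3 and compound 4 are both reported as not active in this assay with no number, so no step can be read between them, and no evidence bears on this result. The compounds shown leave open whether the change from 4-nitrophenyl to 4-methylphenyl alters activity at all.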